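Shortening the Hydroxamic Acid Chain on a Shared Core

The source may hold more compounds than are shown below. What is called first, only, known or untested is meant among the compounds shown, and "the series" means these compounds.

Three compounds share one core and carry a chain that ends in a hydroxamic acid; they differ only in how long that chain is. Compound 1 `Nc1ncnc2c1c(-c1cnc3[nH]ccc3c1)nn2CCCCCCCCC(=O)NO` has a chain of middle length, and in a functional assay on HepG2 cells (Homo sapiens) for inhibition, read by MTT assay, with a stated time of 72 h (a higher number here means a weaker inhibitor, a lower number a stronger inhibitor), compound 1 gives 3050 nM. Compound 2 `Nc1ncnc2c1c(-c1cnc3[nH]ccc3c1)nn2CCCCCC(=O)NO` has the shortest chain, and in this assay compound 2 gives 12900 nM. Compound 3 `Nc1ncnc2c1c(-c1cnc3[nH]ccc3c1)nn2CCCCCCCCCC(=O)NO` has the longest chain, and in this assay compound 3 gives 11700 nM. The two outer chain lengths cannot be told apart, a 1.1-fold lower number from compound 2 to compound 3 (0.04 log units; within the scatter), while the middle length stands apart from both: a 4.2-fold higher number from compound 1 to compound 2 (0.63 log units; beyond the scatter), and a 3.8-fold higher number from compound 1 to compound 3 (0.58 log units; beyond the scatter). Compound 1 is thus the strongest inhibitor among the three.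

Compound 4 `Nc1ncnc2c1c(-c1cnc3[nH]ccc3c1)nn2CCCCCCC(=O)NO` is not yet measured. It comes from compound 3 by the change (hydroxycarbamoyl in place of 3-(hydroxycarbamoyl)propyl on a saturated chain carbon, six bonds along the chain from an aromatic nitrogen). The same change was made once before, from compound 1 to compound 2, where it gave a 4.2-fold higher number from compound 1 to compound 2 (0.63 log units; beyond the scatter). The starting points differ, though: (hydroxycarbamoyl)methyl in place of hydroxycarbamoyl on a saturated chain carbon, eight bonds along the chain from an aromatic nitrogen. The place also differs, five bonds along the chain from an aromatic nitrogen in one case and six bonds in the other, so this is the same kind of change rather than the same one. Compound 4 would carry a chain between those of compound 2 and compound 1, so the earlier loss is not expected to repeat. The estimated step is a 1.5-fold lower number from compound 3 to compound 4 (0.17 log units; within the scatter), resting on compound 1 with 3050 nM and compound 2 with 12900 nM bracketing the new chain length. In this assay compound 4 is expected to give 8000 nM, likely between 3500 nM and 18000 nM.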

Compound 4, half-maximal inhibitory concentration: 10300 nM
Compound 4: middle estimate off by 1.3-fold (0.11 log units), on the low side, within the range that was stated.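

Cutting the chain by the same kind of change does not give the same result at every starting length in this assay, and the outcome depends on which chain the change begins from: the same change on two cores in this assay, a 4.2-fold higher number (0.63 log units; beyond the scatter) from compound 1 to compound 2 and a 1.1-fold lower number (0.06 log units; within the scatter) from compound 3 to compound 4, 4.8-fold (0.68 log units) apart, beyond the scatter of two such steps. A second pair of steps, which lengthens the chain instead of shortening it, tells the same story: the same change on two cores in this assay, a 3.8-fold higher number (0.58 log units; beyond the scatter) from compound 1 to compound 3 and a 1.3-fold lower number (0.10 log units; within the scatter) from compound 2 to compound 4, 4.8-fold (0.68 log units) apart, beyond the scatter of two such steps. Compound 4 cannot be told apart from the two compounds nearest in these numbers, a 1.1-fold lower number from compound 3 to compound 4 (0.06 log units; within the scatter) and a 1.3-fold lower number from compound 2 to compound 4 (0.10 log units; within the scatter), whereas a 3.4-fold higher number from compound 1 to compound 4 (0.53 log units; beyond the scatter) leaves compound 1 the strongest inhibitor of the four, so the effect of a change here cannot be read from its size alone, though this does not show why, and it says nothing about any core other than the shared one.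

Compounds 2, 3 and 4 go against any steady trend with chain length, and the compounds shown leave open how narrow the advantage of compound 1 is, since a chain longer than that of compound 4 and shorter than that of compound 1 is not among them. They also leave open whether the hydroxamic acid end matters to this pattern, which a carboxylic acid in its place at the end of the chain of compound 1 could test.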